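A few compounds are considered here, and "the series" means these few. Any claim that something is new, unique, unknown or untested is made for them only; others in the source may bear on it.

Measured compounds in a functional assay on HT-1080 cells (Homo sapiens) for cytotoxicity, read by MTT assay, with a stated time of 72 h; on this read-out higher numbers stand for weaker inhibition and lower numbers for stronger inhibition:
- compound 1 `COc1cccc(/C=C2\CCC/C(=C\c3ccc(Br)cc3)C2=O)c1OC`: 13700 nM
- compound 2 `COc1cccc(/C=C2\CCC/C(=C\c3cc(OC)c(OC)c(OC)c3)C2=O)c1OC`: 2300 nM
- compound 3 `COc1cc(/C=C2\CCC/C(=C\c3cccc(OC)c3OC)C2=O)ccc1O`: 5900 nM

Compound 1 gives the highest number of the three. Among the compounds with values here, its nearest neighbour is compound 3, reached by the step of a 2.3-fold lower number from compound 1 to compound 3 (0.37 log units; beyond the scatter); compound 2 lies further below it, and no single-point step joins these two, so only the two values themselves are to be compared.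

Compound 4 `COc1cccc(/C=C2\CCC/C(=C\c3ccc(O)c(O)c3)C2=O)c1OC` is not yet measured. It differs from compound 1 in one place: 3,4-dihydroxyphenyl in place of 4-bromophenyl on a double-bonded chain carbon bound to a double-bonded ring carbon. Within the data shown here, the only measured step that bears on this change is the one from compound 1 to compound 3, where a hydroxy-bearing aryl group took the place of the 4-bromophenyl at the same position and the number fell by a 2.3-fold lower number from compound 1 to compound 3 (0.37 log units; beyond the scatter). The change into compound 4 also brings hydroxyl groups onto that aryl ring, so a step of similar size and direction is expected, a 2.5-fold lower number from compound 1 to compound 4 (0.40 log units; beyond the scatter), without any basis in the data for a larger move. Compound 4 is therefore estimated at 5500 nM, with a plausible range from 2200 nM to 13000 nM.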

Compound 4, half-maximal inhibitory concentration: 4700 nM
Beside the measured number, compound 4's estimate is 1.2-fold (0.07 log units) above it; measured number inside the range.
By their numbers in this assay, from the lowest: compound 2; then compounds 4 and 3 (each within the scatter of the next); then compound 1.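

At the aryl group on a double-bonded chain carbon bound to a double-bonded ring carbon, 3,4-dihydroxyphenyl in place of 4-bromophenyl gives a 2.9-fold lower number from compound 1 to compound 4 (0.46 log units; beyond the scatter) in this assay, so a second hydroxy-bearing group moves the number in the same direction as the group in compound 3. Removing the methyl from an oxygen on that aromatic ring gives no readable difference, with a 1.3-fold lower number from compound 3 to compound 4 (0.10 log units; within the scatter) in this assay, so hydrogen and methyl on that oxygen are not told apart by this read-out. No available data explain either step.

From the compounds shown here alone, whether an amine or a carboxylic acid at this place would follow the hydroxy-bearing groups remains open. So does whether a single hydroxyl, as in 4-hydroxyphenyl, would be enough to separate a compound from compound 1.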